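A new group on the sulfonamide nitrogen of compound 2

A few compounds are considered here, and "the series" means these few. Any claim that something is new, unique, unknown or untested is made for them only; others in the source may bear on it.

In a functional assay on MCF7 cells (Homo sapiens) for cytotoxicity, read by sulforhodamine B assay, with a stated time of 72 h (on this read-out lower numbers stand for stronger inhibition and higher numbers for weaker inhibition), compound 1 `Cc1cc(NS(=O)(=O)c2ccc(NCc3coc4ccccc4c3=O)cc2)no1` gives 34500 nM, and compound 3 `O=C1/C(=C/c2coc3ccccc3c2=O)N=C(c2ccccc2)N1c1ccc(S(=O)(=O)Nc2nccs2)cc1` gives 88500 nM. Compound 2 `O=c1c(CNc2ccc(S(=O)(=O)Nc3ccccn3)cc2)coc2ccccc12` reaches only a limit, not a number: > 100000 nM. Compound 4 `Cc1cc(C)nc(NS(=O)(=O)c2ccc(NCc3coc4ccccc4c3=O)cc2)n1` carries 4,6-dimethylpyrimidin-2-yl in place of pyridin-2-yl on a sulfonamide nitrogen. Among the measured compounds shown here, the only measured change at this place is an at least 2.8-fold higher number from compound 1 to compound 2 (0.46 log units; beyond the scatter), which lies beyond the scatter. A single step is thin support, but it shows that the group here can shift the value in this assay, so a modest move toward lower numbers is expected. The expected change is an at least 1.5-fold lower number from compound 2 to compound 4 (0.18 log units; that floor lies within the scatter). For compound 4 the estimate is 65000 nM, with an expected range of 25000 nM to 130000 nM.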

Compound 4, half-maximal inhibitory concentration: 93600 nM
For compound 4 the middle estimate is 1.4-fold (0.16 log units) below the measured one, and the stated range covers the measured number.
By their numbers in this assay, from the lowest: compound 1; then compounds 3 and 4 (each within the scatter of the next). At a limit, above all of these: compound 2.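

In this assay, 4,6-dimethylpyrimidin-2-yl gives this sulfonamide nitrogen a second group with a full number on the higher side of 5-methyl-1,2-oxazol-3-yl (a 2.7-fold higher number from compound 1 to compound 4 (0.43 log units; beyond the scatter)). Against pyridin-2-yl, the change shows no shift beyond the scatter (an at least 1.0-fold lower number from compound 2 to compound 4 (0.02 log units; that floor lies within the scatter)), so the added ring nitrogen and the two methyl groups bring no clear gain. Compound 2 is held at a limit, not a number: the limit of > 100000 nM in this assay, at which 1 of the 4 values shown sits.

From the compounds shown here alone, whether a phenyl or an acetyl group on this nitrogen would bring the number below that of compound 1 stays open. So does whether pyrimidin-2-yl without its methyl groups would read differently from 4,6-dimethylpyrimidin-2-yl.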